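The source may hold more compounds than are shown below. What is called first, only, known or untested is meant among the compounds shown, and "the series" means these compounds.

Compound 1 `COc1cc(-c2cccc3nc(-c4ccccc4)oc23)cc(OC)c1OC` gives 6800 nM in a functional assay on NCI-H460 cells (Homo sapiens) for antiproliferative activity, read by MTT assay, with a stated time of 48 h; a lower number here means a stronger inhibitor, a higher number a weaker inhibitor. Compound 2 `COc1cc(-c2cccc3nc(-c4ccc(Cl)cc4)oc23)cc(OC)c1OC` returns only a limit, > 25000 nM, in this assay. Compound 3 `COc1ccc(-c2cccc3nc(-c4ccc5cc[nH]c5c4)oc23)c(OC)c1OC` likewise returns only a limit, > 25000 nM, in this assay. Compound 2 thus stands at the limit of > 25000 nM in this assay, at which 2 of the 3 values shown sit, with no number of its own. The move to compound 4 `COc1cc(-c2cccc3nc(-c4cccs4)oc23)cc(OC)c1OC` is thiophen-2-yl in place of 4-chlorophenyl on an aromatic carbon. Within the data shown here, the one measured step that bears on it is an at least 3.6-fold higher number from compound 1 to compound 2 (0.56 log units; beyond the scatter), where chloro in place of hydrogen weakened the inhibitor. Since compound 4 drops the chloro, a return toward compound 1 seems likely, though thiophen-2-yl in place of phenyl is itself untested. Compound 4 is therefore expected to give 10000 nM, between 3000 nM and 30000 nM. This amounts to an expected at least 2.5-fold lower number from compound 2 to compound 4 (0.39 log units; beyond the scatter).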

Compound 4, half-maximal inhibitory concentration: 1600 nM
Compound 4: the middle estimate sits 6.3-fold (0.80 log units) above what was measured; the whole stated range lies above it.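

In this assay, thiophen-2-yl in place of phenyl gives a 4.3-fold lower number from compound 1 to compound 4 (0.63 log units; beyond the scatter), so this aromatic carbon admits a five-membered aromatic ring, and a change here can strengthen the inhibitor as well as weaken it. Against 4-chlorophenyl, the same group gives an at least 15-fold lower number from compound 2 to compound 4 (1.19 log units; beyond the scatter). That step is only a bound, since compound 2 returns a limit and no number: the limit of > 25000 nM in this assay, at which 2 of the 4 values shown sit.

The compounds shown leave open whether the gain follows the sulfur atom or the five-membered ring as such. As far as these compounds go, how a furan-2-yl or pyridin-2-yl group would fare on this carbon also remains open.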